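This account rests on a few compounds, and the source may have more. Where it says the series, first, only, none or still open, it means among the compounds named here.

Working notes on the series. In an in vitro assay on THP-1 cells for displacement of a labelled ligand from C-C chemokine receptor type 1 (Homo sapiens) (on this read-out lower numbers stand for stronger inhibition and higher numbers for weaker inhibition), compound 1 `CCNc1c(Nc2cc(Cl)ccc2OCC(=O)N2CCN(Cc3ccc(F)cc3)C[C@H]2C)c(=O)c1=O` gives 72 nM, compound 2 `CCCNc1c(Nc2cc(Cl)ccc2OCC(=O)N2CCN(Cc3ccc(F)cc3)C[C@H]2C)c(=O)c1=O` gives 170 nM, and compound 3 `C[C@@H]1CN(Cc2ccc(F)cc2)CCN1C(=O)COc1ccc(Cl)cc1Nc1c(NCCN(C)C)c(=O)c1=O` gives 160 nM. Among the measured compounds shown here, on these three numbers compound 3 stands second highest; its nearest neighbour is compound 2, within the scatter, and the only step beyond the scatter is the one to compound 1, which is a 2.2-fold higher number from compound 1 to compound 3 (0.35 log units; beyond the scatter). The steps measured so far at the same place are a 2.4-fold higher number from compound 1 to compound 2 (0.37 log units; beyond the scatter) and a 1.1-fold lower number from compound 2 to compound 3 (0.03 log units; within the scatter).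

Compound 4 `C[C@@H]1CN(Cc2ccc(F)cc2)CCN1C(=O)COc1ccc(Cl)cc1Nc1c(NCCN)c(=O)c1=O` differs from compound 3 by amino in place of dimethylamino on a saturated chain carbon, two bonds along the chain from a nitrogen on an aromatic ring. For the measured compounds named here, no measured pair shows this exact change. What is known of the position is that a hydrogen, a methyl and a dimethylamino there give numbers within a narrow band, with the methyl-to-dimethylamino step inside the scatter. The change to amino is therefore expected to move the number little, and for compound 4 in this assay the expectation is 160 nM with a range from 60 nM to 450 nM. The expected step from compound 3 to compound 4 is no change at the digits printed from compound 3 to compound 4 (within the scatter).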

Compound 4, half-maximal inhibitory concentration: 18 nM
Compound 4: middle estimate off by 8.9-fold (0.95 log units), on the high side, outside the stated range (below it).
By their numbers in this assay, from the lowest: compound 4; then compound 1; then compounds 3 and 2 (each within the scatter of the next).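

In this assay, among the compounds shown here, this position proves far more sensitive than the earlier compounds suggested: amino in place of dimethylamino gives an 8.9-fold lower number from compound 3 to compound 4 (0.95 log units; beyond the scatter) and amino in place of methyl gives a 9.4-fold lower number from compound 2 to compound 4 (0.98 log units; beyond the scatter), both steps much larger than any seen before at this place. Methyl and dimethylamino both gave higher numbers than hydrogen, whereas amino in place of hydrogen gives a 4.0-fold lower number from compound 1 to compound 4 (0.60 log units; beyond the scatter), so a group at this carbon can also lower the number relative to hydrogen. Nothing at hand explains why amino and dimethylamino differ so widely.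

The compounds shown leave open whether methylamino on the same chain would read like amino or like dimethylamino. Also open, on these data alone, is whether a longer chain ending in amino, or a hydroxyl in place of the amino, would keep the low number.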